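Tert-butoxycarbonyl for ethyl on the ring nitrogen

A few compounds are considered here, and "the series" means these few. Any claim that something is new, unique, unknown or untested is made for them only; others in the source may bear on it.

- Compound 1 `COc1ccc(-c2coc3cc(OCCCCSC(=S)N4CCN(C(=O)OC(C)(C)C)CC4)ccc3c2=O)cc1` gives 4610 nM
- Compound 2 `CCN1CCN(C(=S)SCCCOc2ccc3c(=O)c(-c4ccc(OC)cc4)coc3c2)CC1` gives 7080 nM
- Compound 3 `COc1ccc(-c2coc3cc(OCCCSC(=S)N4CCN(c5ccccn5)CC4)ccc3c2=O)cc1` gives 17400 nM

Within the data shown here, in a functional assay on PC-3 cells (Homo sapiens) for inhibition, read by MTT assay, with a stated time of 48 h (on this read-out higher numbers stand for weaker inhibition and lower numbers for stronger inhibition), compound 2 at 7080 nM lies within the scatter of compound 1 at 4610 nM on the numbers so far. Among the measured compounds shown here, the only measured step at this ring nitrogen is a 2.5-fold higher number from compound 2 to compound 3 (0.39 log units; beyond the scatter) and it is modest.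

Compound 4 `COc1ccc(-c2coc3cc(OCCCSC(=S)N4CCN(C(=O)OC(C)(C)C)CC4)ccc3c2=O)cc1` is still unmeasured. Its difference from compound 2 is tert-butoxycarbonyl in place of ethyl on an amine nitrogen in a ring and amounts to tert-butoxycarbonyl in place of ethyl on an amine nitrogen in a ring. Compound 1 carries tert-butoxycarbonyl at that nitrogen too, on a different chain, and at 4610 nM shows no gap beyond the scatter from compound 2. No step beyond the scatter is therefore expected in this assay for this change, though a modest move in either direction remains possible. The expected step, an estimate only, is a 1.2-fold lower number from compound 2 to compound 4 (0.09 log units; within the scatter) in this series. For compound 4 the estimated value is 5800 nM with an expected range from 2600 nM to 13000 nM in repeat measurements.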

Compound 4, half-maximal inhibitory concentration: 1970 nM
Estimate against measurement, compound 4: 2.9-fold (0.47 log units) above, outside the stated range (below it).
By their numbers in this assay, from the lowest: compound 4; then compounds 1 and 2 (each within the scatter of the next); then compound 3.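

In this assay, with the chain of compound 2 kept, tert-butoxycarbonyl on the ring nitrogen gives a 3.6-fold lower number from compound 2 to compound 4 (0.56 log units; beyond the scatter), so this change moves the number beyond the scatter, which the comparison with compound 1 on its different chain did not show. The same nitrogen also gives an 8.8-fold lower number from compound 3 to compound 4 (0.95 log units; beyond the scatter), and on this chain the numbers rise from tert-butoxycarbonyl through ethyl to pyridin-2-yl, with every step beyond the scatter. Nothing available explains this order.

From the compounds shown here alone, whether the lower number tracks the carbonyl or the tert-butyl part remains open, and an acetyl group or a free ring amine at this nitrogen would separate the two. Among these compounds, the effect of the chain also remains open, with compound 1 at 4610 nM and compound 4 at 1970 nM as the only pair carrying tert-butoxycarbonyl on different chains.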